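Methanesulfonamido replacing acetamido on the shared core

A few compounds are considered here, and "the series" means these few. Any claim that something is new, unique, unknown or untested is made for them only; others in the source may bear on it.

Of the compounds shown here, three built on one core have been measured in a functional assay on CHO-K1 cells for antagonist activity at C-X-C chemokine receptor type 3 (Homo sapiens), read by FLIPR and calcium flux; a higher number here means a weaker inhibitor, a lower number a stronger inhibitor. Compound 1 `CC1(C)[C@@H]2CC[C@@]1(CS(=O)(=O)N1CCN(c3ccc(C(F)(F)F)cn3)CC1)C(O)C2` gives 158 nM. Compound 2 `CC1(C)[C@@H]2CC[C@@]1(CS(=O)(=O)N1CCN(c3ccc(C(F)(F)F)cn3)CC1)C(F)C2` gives 794 nM, and compound 3 `CC(=O)NC1C[C@H]2CC[C@]1(CS(=O)(=O)N1CCN(c3ccc(C(F)(F)F)cn3)CC1)C2(C)C` gives 2000 nM, the highest number of the three. The step of a 13-fold higher number from compound 1 to compound 3 (1.10 log units; beyond the scatter) is the largest in the set; a 2.5-fold higher number from compound 2 to compound 3 (0.40 log units; beyond the scatter) is smaller, and a 5.0-fold higher number from compound 1 to compound 2 (0.70 log units; beyond the scatter) lies between them.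

Compound 4 `CC1(C)[C@@H]2CC[C@@]1(CS(=O)(=O)N1CCN(c3ccc(C(F)(F)F)cn3)CC1)C(NS(C)(=O)=O)C2` is not yet measured. It differs from compound 3 in one place: methylsulfonyl in place of acetyl on an amine nitrogen. For the measured compounds named here, no measured step exchanges one group on that amine nitrogen for another, so the steps that bear on it are only those that changed the substituent on the saturated ring carbon, namely a 13-fold higher number from compound 1 to compound 3 (1.10 log units; beyond the scatter) and a 2.5-fold higher number from compound 2 to compound 3 (0.40 log units; beyond the scatter), both of which raised the number when the acetamido group entered. Accordingly the expected step is a 1.6-fold higher number from compound 3 to compound 4 (0.20 log units; within the scatter), a move toward a weaker inhibitor that is at most modest, with the scatter leaving room for no change at all. The estimate for compound 4 in this assay is 3200 nM, with a range from 1100 nM to 9500 nM.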

Compound 4, half-maximal inhibitory concentration: 631 nM
For compound 4 the middle estimate is 5.1-fold (0.71 log units) above the measured one; measured number outside the range, below it.
By their numbers in this assay, from the lowest: compound 1; then compounds 4 and 2 (each within the scatter of the next); then compound 3.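

In this assay, for the compounds shown here, the group on the amine nitrogen matters: methylsulfonyl in place of acetyl is the first exchange at that nitrogen, and it lowers the number (a 3.2-fold lower number from compound 3 to compound 4 (0.50 log units; beyond the scatter)), so compound 3 does not speak for every nitrogen-linked group on the saturated ring carbon. Methanesulfonamido and fluoro on that carbon cannot be told apart (a 1.3-fold lower number from compound 2 to compound 4 (0.10 log units; within the scatter)), while hydroxy keeps compound 1 the lowest of the four (a 4.0-fold higher number from compound 1 to compound 4 (0.60 log units; beyond the scatter)). Nothing available explains why methylsulfonyl and acetyl differ here.

Still open, from the compounds shown here alone, is whether a free amine on the saturated ring carbon would come close to compound 1. Also open, going by these compounds, is whether a urea, or a longer chain on the sulfonyl group, would move the number further from that of compound 4.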